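The source may hold more compounds than are shown below. What is called first, only, known or untested is meant among the compounds shown, and "the series" means these compounds.

Compound 1 `CC(=O)Nc1ccn(C2OC(CO[Si](C)(C)C(C)(C)C)C(C#N)C2O[Si](C)(C)C(C)(C)C)c(=O)n1`: in an ADME assay on cells (kidney, Oryctolagus cuniculus) for cytotoxicity (a lower number here means that less compound is tolerated, a higher number that more compound is tolerated), compound 1 gives > 4 ug/mL, which is a limit of the assay.
Compound 2 `CC(C)(C)[Si](C)(C)OCC1OC(n2ccc(N)nc2=O)C(O[Si](C)(C)C(C)(C)C)C1C#N`: in this assay compound 2 gives > 10 ug/mL, also a limit.
Compound 3 `N#C[C@@H]1[C@@H](O)[C@H](n2ccc(=O)[nH]c2=O)O[C@@H]1CO`: in this assay compound 3 gives > 200 ug/mL, again a limit and not a number.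

Compound 3 thus stands at a limit only, (the limit of > 200 ug/mL in this assay, at which 1 of the 3 values shown sits), and no number is known for it. The other two readings are limits as well, the limit of > 10 ug/mL in this assay, at which 1 of the 3 values shown sits, and (the limit of > 4 ug/mL in this assay, at which 1 of the 3 values shown sits). Among the compounds with values here, the one step between measured compounds, a step that the two limits leave unreadable from compound 1 to compound 2, is unreadable, both of its ends being limits, so no measured step in this assay gives a usable size. Compound 4 `N#C[C@H]1[C@@H](O)[C@H](n2ccc(=O)[nH]c2=O)O[C@@H]1CO` differs from compound 3 in one respect: the two compounds have the same atoms and bonds and differ only in configuration as drawn: 1 of 4 stereo elements differ; a stereocentre at a saturated ring carbon is drawn R in compound 3 and S in compound 4. Within the data shown here, no measured pair here concerns a change of configuration alone, so the only guide is the reading of compound 3 itself. The step from compound 3 to compound 4 is expected to be none beyond the scatter, a number no higher from compound 3 to compound 4 (the limit leaves the size open). Compound 4 is expected to give 200 ug/mL in this assay, somewhere between 100 ug/mL and 400 ug/mL, and most probably to be reported again as a limit.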

Compound 4, minimum cytotoxic concentration: > 200 ug/mL
Compound 4 was reported as a limit; the forecaster's own chance of this, stated with the estimate: 85%; the middle value lies on the limit itself.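

Compound 3 and compound 4 both stand at a limit in this assay, and the step between them cannot be read. The compounds shown leave open what concentration of either compound is actually tolerated, and whether the change in configuration alone shifts that reading at all.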